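From Methoxy to Hydroxy on the Shared Core

The source may hold more compounds than are shown below. What is called first, only, known or untested is meant among the compounds shown, and "the series" means these compounds.

The measured compounds:
Compound 1, `O=C1CSc2cc(OCc3ccccc3)ccc2N1`: 71 nM
Compound 2, `COc1ccc2c(c1)SCC(=O)N2`: 42600 nM
Compound 3, `O=C1CSc2cc(OCC3CCCCC3)ccc2N1`: 24 nM

All three were tested in an assay on isolated protein for inhibition of Amine oxidase [flavin-containing] B (Homo sapiens), read by fluorescence and spectrophotometry, with a stated time of 20 min; a lower number here means a stronger inhibitor, a higher number a weaker inhibitor. Compound 2 stands highest of the three numbers. The step of a 600-fold higher number from compound 1 to compound 2 (2.78 log units; beyond the scatter) leads up to it, and the step of a 1800-fold lower number from compound 2 to compound 3 (3.25 log units; beyond the scatter) leads down from it to the lowest number in the set.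

Compound 4, `O=C1CSc2cc(O)ccc2N1`, differs from compound 2 by hydrogen in place of methyl on an oxygen on an aromatic ring. Going by the values given here, two measured steps bear on this change, since both alter what sits on the same oxygen on the aromatic ring: a 600-fold higher number from compound 1 to compound 2 (2.78 log units; beyond the scatter) and a 1800-fold lower number from compound 2 to compound 3 (3.25 log units; beyond the scatter). In each, shrinking the group on that oxygen raised the number by a large margin, and going to hydrogen shrinks it further still. Among the compounds with values here, no measured step removes the methyl itself, so the size of the effect can only be carried over by analogy; it may also be smaller than the earlier steps, since compound 2 already sits at the top of the range. Compound 4 is therefore expected to give a higher number, a step of a 2.3-fold higher number from compound 2 to compound 4 (0.37 log units; beyond the scatter). Compound 4 is estimated at 100000 nM, within a range from 20000 nM to 500000 nM.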

Compound 4, half-maximal inhibitory concentration: 20000 nM
Compound 4: middle estimate off by 5.0-fold (0.70 log units), on the high side, within the range that was stated.
By their numbers in this assay, from the lowest: compound 3; then compound 1; then compound 4; then compound 2.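

In this assay the change from methoxy to hydroxy gives a 2.1-fold lower number from compound 2 to compound 4 (0.33 log units; beyond the scatter), so a smaller group on this oxygen does not always mean a higher number. Across the four compounds, the number does not follow the size of the group on the oxygen: compound 2, with its methyl, stands highest, while compound 4, with only hydrogen there, falls back below it yet remains well above compound 1 and compound 3, which carry the phenyl and cyclohexyl groups on a saturated chain carbon. What this result adds is that the large gain seen with those two groups cannot be read as a steady trend running down from hydrogen through methyl, and nothing at hand explains why hydrogen gives a lower number than methyl on this oxygen.

The compounds shown leave open how the numbers move between methyl and the larger groups, which an ethyl group or a longer chain on the same oxygen would help to trace. They also leave open whether the oxygen itself matters, a question that an amine in its place could address.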